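From methyl to ethyl on compound 2

A few compounds are considered here, and "the series" means these few. Any claim that something is new, unique, unknown or untested is made for them only; others in the source may bear on it.

Measured in an ADME assay on microsomes from liver (Mus musculus) for metabolic stability, read by LC-MS, using NADPH, with stated times of 10 min and 30 min; on this read-out lower numbers stand for slow clearance and higher numbers for fast clearance:
compound 1 `CCC(=O)N[C@@H]1CCCc2c1cncc2N1C(=O)c2ccc(Cl)cc2[C@@H]1C`: < 20.2 mL/min/kg (a limit)
compound 2 `CC(=O)N[C@@H]1CCCc2c1cncc2N1C(=O)c2ccc(Cl)cc2[C@@H]1C`: < 20.2 mL/min/kg (a limit)
compound 3 `CC(=O)N[C@@H]1CCCc2c1cncc2N1C(=O)c2ccc(Cl)cc2[C@H]1C`: 43.5 mL/min/kg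

Compound 2 stands at a limit in this assay, with a reading of < 20.2 mL/min/kg. Compound 1 is also held at a limit, < 20.2 mL/min/kg. Together they make up (the limit of < 20.2 mL/min/kg in this assay, at which 2 of the 3 values shown sit). Only compound 3 gives a true number, 43.5 mL/min/kg.

Compound 4 `CC[C@H]1c2cc(Cl)ccc2C(=O)N1c1cncc2c1CCC[C@H]2NC(C)=O` alters compound 2 in one place, methyl to ethyl: methyl in place of hydrogen on a saturated chain carbon bound to a saturated ring carbon. In words, this is methyl in place of hydrogen on a saturated chain carbon bound to a saturated ring carbon.

Going by the values given here, two measured steps bear on it, and neither measures this change. The closest in kind is a step that the two limits leave unreadable from compound 1 to compound 2, which also exchanges methyl and hydrogen, but on a saturated chain carbon bound to a carbonyl carbon. Among the compounds with values here, the only step with a readable size is an at least 2.1-fold higher number from compound 2 to compound 3 (0.33 log units; beyond the scatter), and behind it lies (the fact that compounds 2 and 3 differ only in the configuration as drawn). With so little to go on, the expected step is an at least 1.0-fold higher number from compound 2 to compound 4 (0.03 log units; that floor lies within the scatter), small and upward, and it may stay within the scatter. Compound 4 may itself read as a limit. For compound 4 the estimated clearance is 22 mL/min/kg, with an expected range of 12 mL/min/kg to 45 mL/min/kg.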

Compound 4, clearance: < 20.2 mL/min/kg
Compound 4 ended at the assay's limit (the forecaster's own chance of this, stated with the estimate: 45%); middle value at least 1.0-fold (0.03 log units) away from the limit.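

In this assay compound 4 gives < 20.2 mL/min/kg, which is a limit of the assay. Compound 2 also stands at a limit, so no step can be read between compound 2 and compound 4. The compounds shown leave open how far the clearance of each lies under that limit, and whether methyl to ethyl changes it.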